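Swapping a bromine for an isopropyl on a shared core

This account rests on a few compounds, and the source may have more. Where it says the series, first, only, none or still open, it means among the compounds named here.

Of the compounds shown here, three built on one shared core have been tested in an ADME assay on Caco-2 cells (Homo sapiens) for permeability, in the apical to basolateral direction; a lower number here means that the compound crosses the layer more slowly, a higher number that the compound crosses the layer faster. Compound 1, `CNC(=O)c1cc(Oc2ccc3nc(Nc4cccc(C(C)(C)C)c4)ncc3c2)ccn1`, carries a tert-butyl group, compound 2, `CNC(=O)c1cc(Oc2ccc3nc(Nc4cccc(OC(F)(F)F)c4)ncc3c2)ccn1`, a trifluoromethoxy group, and compound 3, `CNC(=O)c1cc(Oc2ccc3nc(Nc4ccc(Br)cc4)ncc3c2)ccn1`, a 4-bromophenyl on a nitrogen. In this assay compound 1 gives only a limit of < 1 10^-6 cm/s. Compound 2 likewise gives only a limit of < 1 10^-6 cm/s. Compound 3 also gives only a limit of < 1 10^-6 cm/s. Because all three sit at the limit of < 1 10^-6 cm/s in this assay, at which 3 of the 3 values shown sit, the steps a step that the two limits leave unreadable from compound 1 to compound 2, a step that the two limits leave unreadable from compound 1 to compound 3 and a step that the two limits leave unreadable from compound 2 to compound 3 cannot be read, and compound 3 stands at the same limit as the other two.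

Compound 4, `CNC(=O)c1cc(Oc2ccc3nc(Nc4ccc(C(C)C)cc4)ncc3c2)ccn1`, differs from compound 3 by isopropyl in place of bromo on an aromatic carbon. Going by the values given here, none of the measured steps can say how big such a change is here, since every value so far is a limit; the only guidance is that three different groups on that ring all left the compound at the limit. The expectation is therefore that compound 4 stays close to where compound 3 stands, with the step of a number no lower from compound 3 to compound 4 (the limit leaves the size open) expected to be small. The estimated value for compound 4 in this assay is 1 10^-6 cm/s, within a range from 0.3 10^-6 cm/s to 3 10^-6 cm/s.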

Compound 4, apparent permeability: < 1 10^-6 cm/s
Compound 4: no number, only a limit; the forecaster's own chance of this, stated with the estimate: 55%; the middle value sits exactly at the limit.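

In this assay compound 4 gives < 1 10^-6 cm/s, which is a limit and not a number. The steps to compound 4 from compound 1, compound 2 and compound 3 therefore cannot be read, because all four compounds share one limit: the limit of < 1 10^-6 cm/s in this assay, at which 4 of the 4 values shown sit.

The compounds shown leave open how fast each one actually crosses the layer, and whether isopropyl in place of bromo changes that at all.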